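Imidazole and pyrrole chain ends on a shared core

The source may hold more compounds than are shown below. What is called first, only, known or untested is meant among the compounds shown, and "the series" means these compounds.

Measured so far in a functional assay on K562 cells (Homo sapiens) for antiproliferative activity, read by MTT assay, with a stated time of 48 h (on this read-out higher numbers stand for weaker inhibition and lower numbers for stronger inhibition), for two compounds
compound 1 `Cn1cc(C2=C(c3nn(CCn4ccnc4)c4ncccc34)C(=O)N(c3ccccc3)C2=O)c2ccccc21` gives 26400 nM
compound 2 `Cn1cc(C2=C(c3nn(CCCn4cccc4)c4ncccc34)C(=O)N(c3ccccc3)C2=O)c2ccccc21` gives 36600 nM

For the measured compounds named here, compound 2 stands level with compound 1, the only other measured compound. Going by the values given here, the single measured step of a 1.4-fold higher number from compound 1 to compound 2 (0.14 log units; within the scatter) lies within the scatter. Next is compound 3 `Cn1cc(C2=C(c3nn(CCCCn4ccnc4)c4ncccc34)C(=O)N(c3ccccc3)C2=O)c2ccccc21` with the change (1H-imidazol-1-yl)methyl in place of 1H-pyrrol-1-yl on a saturated chain carbon, three bonds along the chain from an aromatic nitrogen on a saturated chain carbon, three bonds along the chain from an aromatic nitrogen. Among the compounds with values here, with only that small step to go on, no shift beyond the scatter is expected in this assay here. The estimated step is a 1.2-fold lower number from compound 2 to compound 3 (0.09 log units; within the scatter) and so stays within the scatter. Compound 3 is expected at 30000 nM (13000 nM to 70000 nM).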

Compound 3, half-maximal inhibitory concentration: 5030 nM
Compound 3: middle estimate off by 6.0-fold (0.78 log units), on the high side; the whole stated range lies above it.
By their numbers in this assay, from the lowest: compound 3; then compounds 1 and 2 (each within the scatter of the next).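

In this assay, for the compounds shown here, this chain position proves responsive for the first time: a 7.3-fold lower number from compound 2 to compound 3 (0.86 log units; beyond the scatter), where 3-(1H-pyrrol-1-yl)propyl gives way to 4-(1H-imidazol-1-yl)butyl. With the 1H-imidazol-1-yl end kept, the longer chain gives a 5.2-fold lower number from compound 1 to compound 3 (0.72 log units; beyond the scatter), so chain length matters within the imidazole pair. No evidence on the origin of this shift is available.

Open, going by these compounds, is how much of the step from compound 2 belongs to the ring end and how much to the chain. Also open, on these data alone, is whether a longer chain, or an amine as the chain end, extends the shift.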